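A few compounds are considered here, and "the series" means these few. Any claim that something is new, unique, unknown or untested is made for them only; others in the source may bear on it.

Compound 1 `Cc1cccc(NC(=O)N2CCN(c3nc(N)nc4sc(-c5ccc(F)cc5)nc34)CC2)c1` gives 300 nM in a functional assay on cells (Lymphocyte, Homo sapiens) (a higher number here means a weaker inhibitor, a lower number a stronger inhibitor), the lowest of the two numbers available; the nearest is compound 3 `Nc1nc(N2CCN(C(=O)COc3ccc(Cl)cc3)CC2)c2nc(Cc3ccc(F)cc3)sc2n1`, which gives 700 nM in this assay but differs from compound 1 in more than one place. Compound 2 `Nc1nc(N2CCN(S(=O)(=O)c3ccccc3)CC2)c2nc(-c3ccc(F)cc3)sc2n1` returns only a limit, > 10000 nM, in this assay. For the measured compounds named here, the one single-point step recorded is an at least 33-fold higher number from compound 1 to compound 2 (1.52 log units; beyond the scatter), and this large loss rests on (the limit of > 10000 nM in this assay, at which 1 of the 3 values shown sits). Compound 4 `COc1ccc(OCC(=O)N2CCN(c3nc(N)nc4sc(-c5ccc(F)cc5)nc34)CC2)cc1` carries (4-methoxyphenoxy)methyl in place of (3-methylphenyl)amino on a carbonyl carbon. That earlier step concerned a different replacement at the same amine nitrogen, so it bears only loosely here; the values of compound 3 suggest a smaller change. For compound 4 the expected step is a 1.7-fold higher number from compound 1 to compound 4 (0.22 log units; within the scatter), so compound 4 is estimated at 500 nM, within 200 nM to 1500 nM.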

Compound 4, half-maximal inhibitory concentration: 40 nM
Beside the measured number, compound 4's estimate is 13-fold (1.10 log units) above it; the whole stated range lies above it.
By their numbers in this assay, from the lowest: compound 4; then compound 1; then compound 3. At a limit, above all of these: compound 2.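

On a carbonyl carbon, (4-methoxyphenoxy)methyl in place of (3-methylphenyl)amino brings a 7.5-fold lower number from compound 1 to compound 4 (0.88 log units; beyond the scatter) in this assay and so shows that a change here can also lower the number. The change removes the one hydrogen-bond donor of (3-methylphenyl)amino, so that donor is not required for this value. The only loss recorded at this ring nitrogen remains that of compound 2, which is a limit: the limit of > 10000 nM in this assay, at which 1 of the 4 values shown sits.

The compounds shown do not separate the contributions of the methoxy group, the ether oxygen and the lost amide hydrogen. Also open, from the compounds shown here alone, is whether an amine or a carboxylic acid in place of the methoxy group, or a longer chain on the carbonyl carbon, would keep this number.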